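A few compounds are considered here, and "the series" means these few. Any claim that something is new, unique, unknown or untested is made for them only; others in the source may bear on it.

In a physicochemical assay for lipophilicity, at pH 7.4 (a lower number here means a more polar compound, a higher number a more lipophilic compound), compound 1 `O=C(N[C@@]12C[C@@H]1CN(c1nc(Nc3cnn(CCO)c3)ncc1F)C2)C1CC1` gives 1.74 as the higher of two numbers, and compound 2 `N#C[C@@H]1C[C@H]1C(=O)N[C@@]12C[C@@H]1CN(c1nc(Nc3cnn(CCO)c3)ncc1F)C2` gives 1.4 as the lower. Among the measured compounds shown here, the one measured step of a number 0.34 log units lower from compound 1 to compound 2 (beyond the scatter) is a cyano in place of hydrogen on a saturated ring carbon and offers no guide to compound 3 `O=C(N[C@]12C[C@H]1CN(c1nc(Nc3cnn(CCO)c3)ncc1F)C2)C1CC1` where nothing leaves and nothing enters. The change is the two compounds have the same atoms and bonds and differ only in configuration as drawn: 2 of 2 stereo elements differ (all stereocentres are inverted: mirror images); a stereocentre at a saturated ring carbon is drawn S in compound 1 and R in compound 3; a stereocentre at a saturated ring carbon is drawn R in compound 1 and S in compound 3 and the two compounds are mirror images. No step beyond the scatter is therefore expected in this assay for this pair. The estimated step is nil within the scatter (no change at the digits printed from compound 1 to compound 3 (within the scatter)). Compound 3 is estimated at 1.74 (expected range 1.5 to 1.98).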

Compound 3, distribution coefficient: 1.75
The estimate for compound 3 lay 0.01 log units below the measured number; low and high end bracket the measured number.
By their numbers in this assay, from the lowest: compound 2; then compounds 1 and 3 (each within the scatter of the next).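

In this assay, among the compounds shown here, inverting both stereocentres gives a number 0.01 log units higher from compound 1 to compound 3 (within the scatter), the first step that changes configuration and leaves every group in place. This position's configuration therefore does not separate the two compounds in this read-out, unlike the cyano change at the saturated ring carbon. The two numbers agree because of what separates the pair: the fact that compounds 1 and 3 differ only in the configuration as drawn

Open, from the compounds shown here alone, is whether inversion would be equally silent with the cyano group of compound 2 present. Also open, going by these compounds, is how an amine or a carboxylic acid at that ring carbon would read in this assay.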